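Chain Extension on the Shared Core: Cytotoxicity Notes

The compounds below may be only part of what the source reports. "The series", "measured", "known", "first", "only" and "open" are said of these compounds alone.

Measured compounds:
compound 1 `CCCCc1c(F)c(N)c2c(=O)cc(-c3ccc(N)c(F)c3)oc2c1F`: > 100000 nM
compound 2 `CCCCCCc1c(F)c(N)c2c(=O)cc(-c3ccc(N)c(F)c3)oc2c1F`: 21000 nM
compound 3 `COCc1c(F)c(N)c2c(=O)cc(-c3ccc(N)c(F)c3)oc2c1F`: > 100000 nM

In a functional assay on HeLa cells (Homo sapiens) for cytotoxicity, read by neutral red uptake, with a stated time of 3 days (a lower number here means a stronger inhibitor, a higher number a weaker inhibitor), compound 1 gives > 100000 nM, which is a limit of the assay and not a number. Compound 2 gives 21000 nM. Compound 3 gives > 100000 nM, again a limit. The change ethyl in place of hydrogen on a saturated chain carbon, four bonds along the chain from an aromatic carbon produced an at least 4.7-fold lower number from compound 1 to compound 2 (0.67 log units; beyond the scatter); its size is only a bound because of the limit of > 100000 nM in this assay, at which 2 of the 3 values shown sit. The two cores differ by methoxy in place of propyl on a saturated chain carbon bound to an aromatic carbon, and that gives a step that the two limits leave unreadable from compound 1 to compound 3. The pair of compound 2 and compound 3 shows an at least 4.7-fold higher number from compound 2 to compound 3 (0.67 log units; beyond the scatter).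

Compound 4 `CCCOCc1c(F)c(N)c2c(=O)cc(-c3ccc(N)c(F)c3)oc2c1F` is not yet measured. It differs from compound 3 by ethyl in place of hydrogen on a saturated chain carbon bound to an oxygen on a saturated carbon, the same kind of change as between compound 1 and compound 2, though here placed on a saturated chain carbon bound to an oxygen on a saturated carbon rather than four bonds along the chain from an aromatic carbon. A step of an at least 2.0-fold lower number from compound 3 to compound 4 (0.30 log units; that floor lies within the scatter) is expected, resting on an at least 4.7-fold lower number from compound 1 to compound 2 (0.67 log units; beyond the scatter). Compound 4 is estimated at 50000 nM, between 12000 nM and 120000 nM.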

Compound 4, half-maximal inhibitory concentration: 78000 nM
Compound 4: the middle estimate sits 1.6-fold (0.19 log units) below what was measured; low and high end bracket the measured number.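

In this assay ethyl in place of hydrogen gives a step in the same direction on both cores, but the two steps cannot be told apart in size: the same change on two cores in this assay, an at least 4.7-fold lower number (0.67 log units; beyond the scatter) from compound 1 to compound 2 and an at least 1.2-fold lower number (0.10 log units; that floor lies within the scatter) from compound 3 to compound 4; the limit leaves it open whether they differ

The new step reads an at least 1.2-fold lower number from compound 3 to compound 4 (0.10 log units; that floor lies within the scatter) and is only a floor, so it does not show that the size of the step on the core of compound 1 carries over: the limit of > 100000 nM in this assay, at which 2 of the 4 values shown sit.

Propoxy in place of a saturated chain gives a 3.7-fold higher number from compound 2 to compound 4 (0.57 log units; beyond the scatter) and an at least 1.2-fold lower number from compound 1 to compound 4 (0.10 log units; that floor lies within the scatter) with the second again only a floor.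

As far as these compounds go, what a longer chain on the oxygen would give in this assay stays open. From the compounds shown here alone, the effect of an amine or a carboxylic acid at this place is also open.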